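Methyl on the Amide Nitrogen of a Tetrazole Chromone Amide

A few compounds are considered here, and "the series" means these few. Any claim that something is new, unique, unknown or untested is made for them only; others in the source may bear on it.

Measured compounds:
- compound 1, `O=C(Nc1nnn[nH]1)c1cc(=O)c2ccccc2o1`: 100%
- compound 2, `Cn1nnnc1NC(=O)c1cc(=O)c2ccccc2o1`: 0%
- compound 3, `N#Cc1ccc2oc(C(=O)Nc3nnn[nH]3)cc(=O)c2c1`: 100%

The read-out is a functional assay on the whole organism for inhibition, with Rattus norvegicus as the target, with a stated time of 30 min, at a dose of 1 mg/kg by the intravenous route; on this read-out higher numbers stand for more inhibition at the one dose given (going by the name of the read-out) and lower numbers for less inhibition. On it compound 1 stands level with compound 3, the two together at the top of the three numbers, while compound 2 lies far beneath them. Two steps are known. Adding a cyano group on an aromatic carbon leaves the number where it was: no change at the digits printed from compound 1 to compound 3 (within the scatter). Putting a methyl on an aromatic nitrogen of the tetrazole wipes it out: a number 100 percentage points lower from compound 1 to compound 2 (beyond the scatter).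

Compound 4, `CN(C(=O)c1cc(=O)c2ccccc2o1)c1nnn[nH]1`, has not been measured. It differs from compound 1 by methyl in place of hydrogen on an amide-type nitrogen. Going by the values given here, no measured step touches this nitrogen, so the only guide is the methyl step from compound 1 to compound 2, which was large and downward. A methyl in a different place need not behave the same way, so the expectation is a sizeable fall with wide uncertainty: compound 4 is expected to give 30%, between 0% and 90%, which would mean an expected step of a number 70 percentage points lower from compound 1 to compound 4 (beyond the scatter).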

Compound 4, a percentage reported as inhibition, in the whole organism at one dose (the size of the read-out at that dose, not a potency): 0%
Compound 4: the middle estimate sits 30 percentage points above what was measured; measured number inside the range.
By their numbers in this assay, from the lowest: compounds 2 and 4 (each within the scatter of the next); then compounds 1 and 3 (each within the scatter of the next).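

In this assay, the nitrogen of the amide-type link turns out to be a second place where a single methyl is enough to lose the effect: a number 100 percentage points lower from compound 1 to compound 4 (beyond the scatter). Together with a number 100 percentage points lower from compound 1 to compound 2 (beyond the scatter), this means that both methyl steps from compound 1, one on an aromatic nitrogen and one on the amide-type nitrogen, lead to a large fall, so the earlier drop was not unique to one nitrogen. Nothing shown here explains why replacing the amide hydrogen has this effect.

The compounds shown leave open whether a longer chain such as ethyl, or a small group such as hydroxyl, on this nitrogen would fare any differently. They also leave open whether compound 4 would show any inhibition at a higher dose, since only one dose is reported.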